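The source may report more compounds than this note shows. Statements on the series, on what has been measured and on what is new or still open speak of the compounds shown alone.

Measured in a functional assay on DU-145 cells (Homo sapiens) for inhibition, read by trypan blue exclusion, with a stated time of 96 h; on this read-out lower numbers stand for stronger inhibition of growth and higher numbers for weaker inhibition of growth:
- Compound 1 `Cc1ccc(S/C(=C/c2ccc(Br)cc2)C(=O)c2ccc(Cl)cc2)cc1`: 25000 nM
- Compound 2 `Cc1ccc(S/C(=C/c2ccc(-c3ccccc3)cc2)C(=O)c2ccc(Br)cc2)cc1`: 50000 nM

Compound 2, at 50000 nM, stands within the usual scatter of compound 1, at 25000 nM, so these two values cannot be told apart. Compound 3 `Cc1ccc(S/C(=C/c2ccc(-c3ccccc3)cc2)C(=O)c2ccc(Cl)cc2)cc1` has not yet been measured. It is compound 2 with chloro in place of bromo on an aromatic carbon, para to a large group (chloro in place of bromo on an aromatic carbon).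

Going by the values given here, no pair of measured compounds differs in one place only, so the data give no direct measure of this change. In this assay, no step beyond the scatter is expected, in either direction. The estimated step of a 1.3-fold lower number from compound 2 to compound 3 (0.10 log units; within the scatter) is therefore small. For compound 3, the expected value is 40000 nM, with an estimated range from 18000 nM to 90000 nM.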

Compound 3, concentration for 50% growth inhibition: 50000 nM
Compound 3: middle estimate off by 1.3-fold (0.10 log units), on the low side; low and high end bracket the measured number.
By their numbers in this assay, from the lowest: compounds 1, 2 and 3 (each within the scatter of the next).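

In this assay, the exchange of 4-bromophenyl for 4-chlorophenyl on the carbonyl gives no change at the digits printed from compound 2 to compound 3 (within the scatter), so at this position the two halogens cannot be told apart while the biphenyl-bearing side stays fixed. Going by these compounds alone, compound 3 also provides the first comparison that differs in one place on the other side of the molecule: phenyl in place of bromo, with chloro held constant, gives a 2.0-fold higher number from compound 1 to compound 3 (0.30 log units; within the scatter), so this exchange cannot be separated from the scatter either. Nothing measured here accounts for these results.

From the compounds shown here alone, all the values remain high and close together, so it stays open whether any change at these positions can produce a step beyond the scatter. An amine or a carboxylic acid in place of the halogen at either position might answer this, but the compounds shown do not say.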